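The compounds below may be only part of what the source reports. "The series", "measured", "known", "first", "only" and "open" are said of these compounds alone.

In a functional assay on HCT-116 cells (Homo sapiens) for cytotoxicity, read by sulforhodamine B assay, with a stated time of 48 h (a lower number here means a stronger inhibitor of growth, a higher number a weaker inhibitor of growth), the measured compounds stand as follows:

Compound 1 `ClCc1ccccc1Cn1cnc2c(Cl)nc(Cl)nc21`: 380 nM
Compound 2 `ClCc1cccc(Cn2cnc3c(Cl)nc(Cl)nc32)c1`: 3090 nM
Compound 3 `Nc1nc(Cl)c2ncn(Cc3ccccc3CCl)c2n1`: a limit of the assay, > 100000 nM

Compound 1 and compound 2 share the same atoms joined differently; the difference between the two cores is not broken down here. Compound 2 has the highest number of the two. From compound 1 to compound 3 the change is amino in place of chloro on an aromatic carbon, and the step is an at least 260-fold higher number from compound 1 to compound 3 (2.42 log units; beyond the scatter), resting on (the limit of > 100000 nM in this assay, at which 1 of the 3 values shown sits).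

Compound 4 `Nc1nc(Cl)c2ncn(Cc3cccc(CCl)c3)c2n1` is still to be measured. It differs from compound 2 by amino in place of chloro on an aromatic carbon, the same change, at the same place, as from compound 1 to compound 3. For compound 4 a step of a 65-fold higher number from compound 2 to compound 4 (1.81 log units; beyond the scatter) is expected, because of an at least 260-fold higher number from compound 1 to compound 3 (2.42 log units; beyond the scatter). Compound 4 is therefore estimated at 200000 nM, probably again only a limit.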

Compound 4, concentration for total growth inhibition: 3890 nM
For compound 4 the middle estimate is 51-fold (1.71 log units) above the measured one, outside the stated range (below it).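

In this assay, amino in place of chloro on the aromatic carbon between two ring nitrogen atoms gives a 1.3-fold higher number from compound 2 to compound 4 (0.10 log units; within the scatter), so on this core the change makes no measurable difference. The same change therefore cannot be carried from one core to the other as a fixed step, since the two steps clearly differ: the same change on two cores in this assay, an at least 260-fold higher number (2.42 log units; beyond the scatter) from compound 1 to compound 3 and a 1.3-fold higher number (0.10 log units; within the scatter) from compound 2 to compound 4, at least 200-fold (2.32 log units) apart, beyond the scatter of two such steps. The value of compound 3 is a limit of the assay, so the full size of the earlier step stays unknown, and two cores cannot show why the change behaves differently: the limit of > 100000 nM in this assay, at which 1 of the 4 values shown sits.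

The compounds shown leave open how a methoxy group or a dimethylamino group on that same carbon would behave on either core.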